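Nitro to methyl on the cinnamoyl phenyl ring

This account rests on a few compounds, and the source may have more. Where it says the series, first, only, none or still open, it means among the compounds named here.

The series shares the core seen in compound 1 `O=C(/C=C\c1cccc(O)c1)N1N=C(c2ccncc2)OC1c1c[nH]c2ccccc12` and compound 2 `O=C(/C=C\c1ccc([N+](=O)[O-])cc1)N1N=C(c2ccncc2)OC1c1c[nH]c2ccccc12`, and is read in an ADME assay on PANC-1 cells (Homo sapiens) for cytotoxicity, read by MTT assay, with a stated time of 48 h; on this read-out lower numbers stand for stronger inhibition of growth and higher numbers for weaker inhibition of growth. In this assay compound 1 reaches only the limit of > 30 ug/mL, not a number. Compound 2 likewise reaches only the limit of > 30 ug/mL. The step that the two limits leave unreadable from compound 1 to compound 2 therefore cannot be sized, since the limit of > 30 ug/mL in this assay, at which 2 of the 2 values shown sit, holds both values. Compound 2 stands at that limit with no number behind it.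

Compound 3 `Cc1ccc(/C=C\C(=O)N2N=C(c3ccncc3)OC2c2c[nH]c3ccccc23)cc1` differs from compound 2 by methyl in place of nitro on an aromatic carbon. Among the compounds with values here, the only measured step, from compound 1 to compound 2, is unreadable, so no sized step bears on this change; the expectation for compound 3 rests on the limit of compound 2 at > 30 ug/mL and is that the read-out stays at the limit. Compound 3 is thus expected at 30 ug/mL, with a range from 15 ug/mL to 60 ug/mL. The step of a number no higher from compound 2 to compound 3 (the limit leaves the size open) is expected to lie within the scatter.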

Compound 3, concentration for 50% growth inhibition: > 30 ug/mL
Compound 3 was reported as a limit; the forecaster's own chance of this, stated with the estimate: 80%; the middle value sits exactly at the limit.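

In this assay, within the data shown here, compound 3 gives > 30 ug/mL, a limit and not a number, so no step from compound 1 or compound 2 to compound 3 can be read. The compounds shown leave open how strongly compound 1, compound 2 and compound 3 each inhibit growth, and all three share one reading: the limit of > 30 ug/mL in this assay, at which 3 of the 3 values shown sit.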